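Series notes: a fluoro for hydrogen step from compound 1

A few compounds are considered here, and "the series" means these few. Any claim that something is new, unique, unknown or untested is made for them only; others in the source may bear on it.

Compound 1, `COc1ccc(-c2ccc(-c3ccc(C(=N)N)cc3)s2)cc1`, gives "not determined" (no result reported) in a functional assay on IGROV-1 cells (Homo sapiens) for inhibition, read by sulforhodamine B assay, with a stated time of 48 h (on this read-out lower numbers stand for stronger inhibition of growth and higher numbers for weaker inhibition of growth), so it stands at no number of its own in this series. Two related compounds give the measured frame. Compound 2, `N=C(N)c1ccc(-c2ccc(-c3ccc(F)cc3)s2)cc1`, gives 1790 nM in this assay. Compound 3, `COc1cc(OC)cc(-c2ccc(-c3ccc(C(=N)N)c(F)c3)s2)c1`, gives 484 nM in this assay. Going by the values given here, compounds 2 and 3 differ from each other in more than one place, so no single step between them is recorded; their two numbers alone are what the series shows.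

The new compound is compound 4, `COc1ccc(-c2ccc(-c3ccc(C(=N)N)c(F)c3)s2)cc1`. It differs from compound 1 by fluoro in place of hydrogen on an aromatic carbon, the fluoro entering on an aromatic carbon of the six-membered aromatic ring of carbon only, ortho to a group of 3 heavy atoms and meta to a large group. Among the compounds with values here, no step for this kind of change is recorded between measured compounds, and compound 1 itself has no number. Compound 3 carries the fluoro at the same place and gives 484 nM, the nearest anchor. For compound 4 a number of roughly that order in this assay is expected, with no step beyond the scatter assumed in either direction, and the estimate is 700 nM, within 250 nM to 2500 nM.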

Compound 4, concentration for 50% growth inhibition: 4380 nM
Compound 4: the middle estimate sits 6.3-fold (0.80 log units) below what was measured; the measured number lies above the stated range.
By their numbers in this assay, from the lowest: compound 3; then compound 2; then compound 4.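

In this assay, going by these compounds alone, compound 1 has no number, so no step to compound 4 can be read. The compounds shown leave open what fluoro in place of hydrogen does to growth inhibition on the core of compound 1. Nothing at hand bears on the result of compound 4.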